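A few compounds are considered here, and "the series" means these few. Any claim that something is new, unique, unknown or untested is made for them only; others in the source may bear on it.

Compound 1 `CC(C)N(Cc1cccc(OCCCCCC(=O)O)c1)C(=O)c1ccc(-c2cccc(-c3ccccc3)c2)cc1` in an ADME assay on HepG2 cells (Homo sapiens) for cytotoxicity, read by CellTiter-Glo and resazurin assay, with a stated time of 72 h (a lower number here means that less compound is needed, a higher number that more compound is needed for the effect), reports only a limit, > 26000 nM.
Compound 2 `COc1ccc(F)c(-c2ccc(C(=O)N(Cc3cccc(OCCCCCC(=O)O)c3)C(C)C)cc2)c1` in this assay reports only a limit, > 26000 nM.
Compound 3 `CCOC(=O)CCCCCOc1cccc(CN(C(=O)c2ccc(-c3cccc(-c4ccccc4)c3)cc2)C(C)C)c1` in this assay reports only a limit, > 26000 nM.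

Compound 3 therefore stands nowhere on a scale of numbers: its result in this assay is a limit, and it shares that position with the other two values shown, because of the limit of > 26000 nM in this assay, at which 3 of the 3 values shown sit. The two measured steps that lead into this set are a step that the two limits leave unreadable from compound 1 to compound 2 and a step that the two limits leave unreadable from compound 1 to compound 3; neither can be read, since a step between two limits has no size.

Compound 4 `CCOC(=O)CCCCCOc1cccc(CN(C(=O)c2ccc(-c3cc(OC)cc(OC)c3)cc2)C(C)C)c1` differs from compound 3 in one place: 3,5-dimethoxyphenyl in place of 3-phenylphenyl on an aromatic carbon. Within the data shown here, no measured step bears directly on this change, and the steps that do exist give no readable size. What the three values show is that none of these compounds reached a measurable effect in this assay within the tested range, and nothing in the shown data points compound 4 away from that. Compound 4 is therefore expected to behave as a step that the limit leaves unreadable from compound 3 to compound 4, and its estimated value in this assay is 30000 nM, within 15000 nM to 60000 nM.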

Compound 4, half-maximal effective concentration: > 26000 nM
Compound 4: no number, only a limit; the forecaster's own chance of this, stated with the estimate: 85%; the middle value does not contradict the limit.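

No new step can be read from compound 3 to compound 4, since both report only a limit in this assay: the limit of > 26000 nM in this assay, at which 4 of the 4 values shown sit.

The compounds shown leave open how far these four actually differ in cytotoxicity, and which change to the shared core, if any, would give a measurable value.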